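The source may hold more compounds than are shown below. What is called first, only, known or untested is meant among the compounds shown, and "the series" means these compounds.

Compound 1 `O=C(O)CCCCCC(=O)N1CCC2(CC1)CCN(c1ccncc1)CC2` carries an acid-bearing chain on the nitrogen of its core. In a functional assay for inhibition, with Homo sapiens as the target (on this read-out higher numbers stand for weaker inhibition and lower numbers for stronger inhibition), compound 1 gives 4550 nM. Compound 2 `O=C(O)CCCCCCC(=O)N1CCC2(CC1)CCN(c1ccncc1)CC2` differs from it in one place, (carboxymethyl in place of carboxy on a saturated chain carbon, five bonds along the chain from a carbonyl carbon), and in this assay compound 2 gives 17800 nM; the step is a 3.9-fold higher number from compound 1 to compound 2 (0.59 log units; beyond the scatter), so lengthening the chain here made inhibition weaker.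

Compound 3 `N=C(N)c1ccc(C(=O)N2CCC3(CCN(C(=O)CCC(=O)O)CC3)CC2)cc1` is built on a different core; the difference between the core of compound 3 and the core of compound 1 is not broken down here. In this assay compound 3 gives 13800 nM, which sits within the scatter of compound 2, while the gap to compound 1 lies beyond the scatter.

Compound 4 `N=C(N)c1ccc(C(=O)N2CCC3(CCN(C(=O)CCCC(=O)O)CC3)CC2)cc1`, not yet measured, is compound 3 with one change: carboxymethyl in place of carboxy on a saturated chain carbon, two bonds along the chain from a carbonyl carbon. This is the same kind of change as from compound 1 to compound 2, not the same one, since in compound 1 the carbon sits five bonds along the chain from a carbonyl carbon, whereas in compound 3 it sits two bonds along the chain from a carbonyl carbon.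

The step from compound 3 to compound 4 is expected to be a 2.5-fold higher number from compound 3 to compound 4 (0.40 log units; beyond the scatter), a weakening of similar direction to the earlier one. That expectation rests on a 3.9-fold higher number from compound 1 to compound 2 (0.59 log units; beyond the scatter); the different place and core leave it less certain, so the guess is held nearer to compound 3. Compound 4 is therefore expected to give about 35000 nM, most likely between 12000 nM and 100000 nM.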

Compound 4, half-maximal inhibitory concentration: 10300 nM
For compound 4 the middle estimate is 3.4-fold (0.53 log units) above the measured one; the whole stated range lies above it.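

In this assay the new step is a 1.3-fold lower number from compound 3 to compound 4 (0.13 log units; within the scatter), so on this core, at this place on the chain, the read-out does not separate the carboxymethyl group from the carboxy group it replaces. The weakening seen when the same kind of change was made on the core of compound 1 therefore did not carry over to the core of compound 3, and the two steps really do differ: the same change on two cores in this assay, a 3.9-fold higher number (0.59 log units; beyond the scatter) from compound 1 to compound 2 and a 1.3-fold lower number (0.13 log units; within the scatter) from compound 3 to compound 4, 5.2-fold (0.72 log units) apart, beyond the scatter of two such steps This shows that a step measured on one core cannot simply be transferred to another in this series, but it does not show why, since the two pairs differ both in their core and in how far along the chain the change sits, and each is a single pair of compounds.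

The compounds shown leave open whether a still longer chain on the core of compound 3 would weaken inhibition as the step to compound 2 did, or whether the lack of a clear step persists there too. They also leave open what happens on either core when a methyl ester or a primary amide stands in place of the carboxylic acid at the end of the chain.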